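Methylation of the phenol in a cyclopropane-diamide series

The source may report more compounds than this note shows. Statements on the series, on what has been measured and on what is new or still open speak of the compounds shown alone.

Compound 1 `CN(C)C(=O)c1cc2cnc(Nc3ccc(NC(=O)C4(C(=O)Nc5ccc(Cl)c(C(F)(F)F)c5)CC4)cc3)nc2n1C1CCCC1`: 6.9%
Compound 2 `CN(C)C(=O)c1cc2cnc(Nc3ccc(NC(=O)C4(C(=O)Nc5cccc(Br)c5)CC4)cc3)nc2n1C1CCCC1`: 29.1%
Compound 3 `CN(C)C(=O)c1cc2cnc(Nc3ccc(NC(=O)C4(C(=O)Nc5ccc(O)cc5)CC4)cc3)nc2n1C1CCCC1`: 91.5%

The three measured compounds share one core and differ only in the aryl group on the amide-type nitrogen. In a functional assay on T47D cells (Homo sapiens) for inhibition, read by CCK-8 assay, with a stated time of 72 h, tested at 1 uM (a lower number here means less inhibition of growth, a higher number more inhibition of growth at the concentration tested), compound 1 gives 6.9%, the lowest of the three numbers. Compound 2 gives 29.1%, and the step of a number 22.2 percentage points higher from compound 1 to compound 2 (beyond the scatter) is modest. Compound 3 gives 91.5%, the highest of the three; the steps of a number 84.6 percentage points higher from compound 1 to compound 3 (beyond the scatter) and a number 62.4 percentage points higher from compound 2 to compound 3 (beyond the scatter) are both large, so compound 3 stands clearly apart from the other two.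

Compound 4 `COc1ccc(NC(=O)C2(C(=O)Nc3ccc(Nc4ncc5cc(C(=O)N(C)C)n(C6CCCC6)c5n4)cc3)CC2)cc1` is the next member. It differs from compound 3 by methyl in place of hydrogen on an oxygen on an aromatic ring. Among the compounds with values here, none of the measured steps alters this hydroxy group, so no step bears directly on the change; the measured steps only show that the aryl group on the amide-type nitrogen can move the number over a wide span. The change here is small, a single carbon entering, but the hydroxy group of compound 3 is the feature that sets it apart. Compound 4 is therefore expected to remain well above compounds 1 and 2 while giving up part of the margin of compound 3, an expected step of a number 21.5 percentage points lower from compound 3 to compound 4 (beyond the scatter) in this assay. The estimate for compound 4 is 70%, within 40% to 95%.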

Compound 4, percent growth inhibition at one concentration: 76.4%
Beside the measured number, compound 4's estimate is 6.4 percentage points below it, and the stated range covers the measured number.
By their numbers in this assay, from the lowest: compound 1; then compound 2; then compound 4; then compound 3.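

In this assay, the change from hydroxy to methoxy comes with a number 15.1 percentage points lower from compound 3 to compound 4 (beyond the scatter) and so has a measurable but modest cost, which shows that the hydrogen on this oxygen accounts for only part of the high number of compound 3. The 4-methoxyphenyl group still holds a wide lead over the two halogen-bearing aryl groups, with a number 47.3 percentage points higher from compound 2 to compound 4 (beyond the scatter) and a number 69.5 percentage points higher from compound 1 to compound 4 (beyond the scatter), so among these four compounds a high number does not depend on a free hydroxy group. No evidence is available here on what lies behind the step from hydroxy to methoxy.

The compounds shown leave open whether a longer chain on this oxygen, such as ethoxy or 2-methoxyethoxy, would hold the number near that of compound 4 or lower it further, and whether an amine or a carboxylic acid in place of the hydroxy group would do as well as the oxygen-bearing groups. They also leave open how 3-hydroxyphenyl would compare with 4-hydroxyphenyl, and with all four compounds read at a single concentration, the steps give no measure of potency across a range of concentrations.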